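Swapping the nitro for phenyl on a 5-lipoxygenase inhibitor

The source may report more compounds than this note shows. Statements on the series, on what has been measured and on what is new or still open speak of the compounds shown alone.

Compound 1, `CCCCCCC(Sc1nc(Cl)cc(Nc2nc(-c3ccc(C)cc3)cs2)n1)C(=O)O`, gives 200 nM in an assay for inhibition of Polyunsaturated fatty acid 5-lipoxygenase (Homo sapiens), read by HPLC, with stated times of 15 min and 10 min; a lower number here means a stronger inhibitor, a higher number a weaker inhibitor.
Compound 2, `CCCCCCC(Sc1nc(Cl)cc(Nc2nc(-c3ccc([N+](=O)[O-])cc3)cs2)n1)C(=O)O`, gives 1400 nM in this assay.

Going by the values given here, of the two measured compounds, compound 2 has the higher number, and the only measured step, a 7.0-fold higher number from compound 1 to compound 2 (0.85 log units; beyond the scatter), is the one that leads to it. Compound 3, `CCCCCCC(Sc1nc(Cl)cc(Nc2nc(-c3ccc(-c4ccccc4)cc3)cs2)n1)C(=O)O`, is reached from compound 2 by a single change: phenyl in place of nitro on an aromatic carbon. Among the compounds with values here, no measured pair holds a phenyl at this place, so the one step that bears on the change is the methyl-to-nitro step from compound 1 to compound 2, which shows that the group at this position moves the number well beyond the scatter. Phenyl, like methyl, carries no hydrogen-bond acceptors, so the expectation is that compound 3 falls back toward compound 1, giving an expected step of a 3.5-fold lower number from compound 2 to compound 3 (0.54 log units; beyond the scatter). Compound 3 is therefore estimated at 400 nM, within a range of 100 nM to 2000 nM.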

Compound 3, half-maximal inhibitory concentration: 300 nM
Compound 3: middle estimate off by 1.3-fold (0.12 log units), on the high side, and the stated range covers the measured number.
By their numbers in this assay, from the lowest: compounds 1 and 3 (each within the scatter of the next); then compound 2.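

In this assay phenyl in place of nitro gives a 4.7-fold lower number from compound 2 to compound 3 (0.67 log units; beyond the scatter) and so shows that the number can come back down at this position even when a larger group goes on. Phenyl in place of methyl gives a 1.5-fold higher number from compound 1 to compound 3 (0.18 log units; within the scatter) and so adds a whole aromatic ring here with no change that stands out from the usual scatter. Among these three compounds, then, nitro is the group that stands apart, and the size of the group does not by itself set the number, since nitro has fewer heavy atoms than phenyl.

From the compounds shown here alone, whether an amine, a hydroxyl or a carboxylic acid at this place would behave like nitro or like methyl and phenyl stays open. Nothing measured here says why nitro differs from the other two groups.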